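Aroyl variation on the shared core, cytotoxicity notes

The source may report more compounds than this note shows. Statements on the series, on what has been measured and on what is new or still open speak of the compounds shown alone.

The series keeps one core and varies the group on a carbonyl carbon. Compound 1 `COc1cc(C(=O)C2Sc3nnc(-c4cc(OC)c(OC)c(OC)c4)n3NC2c2ccco2)cc(OC)c1OC` carries 3,4,5-trimethoxyphenyl there; in a functional assay on PC-3 cells (Homo sapiens) for cytotoxicity, read by MTT assay, with a stated time of 48 h (a lower number here means a stronger inhibitor, a higher number a weaker inhibitor), compound 1 gives 52200 nM. Compound 2 `COc1cc(-c2nnc3n2NC(c2ccco2)C(C(=O)c2cccc4ccccc24)S3)cc(OC)c1OC` carries naphthalen-1-yl at the same place. In this assay compound 2 reaches only a limit of the assay, > 100000 nM. Within the data shown here, the step of an at least 1.9-fold higher number from compound 1 to compound 2 (0.28 log units; that floor lies within the scatter) is the only measured step, and it is bounded by the limit of > 100000 nM in this assay, at which 1 of the 2 values shown sits. Compound 3 `COc1cc(-c2nnc3n2NC(c2ccco2)C(C(=O)c2ccc(F)c(F)c2)S3)cc(OC)c1OC` differs from compound 2 by 3,4-difluorophenyl in place of naphthalen-1-yl on a carbonyl carbon. Among the measured compounds shown here, no measured step involves 3,4-difluorophenyl; the single step at this carbonyl carbon runs between two other aryl groups and ends at the limit, so it fixes the size of an exchange here only as a floor. A step of an at least 1.2-fold lower number from compound 2 to compound 3 (0.09 log units; that floor lies within the scatter) is therefore expected, with the number for compound 3 likely to stay near the limit. Compound 3 is estimated at 80000 nM, within 30000 nM to 200000 nM.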

Compound 3, half-maximal inhibitory concentration: 36000 nM
Estimate against measurement, compound 3: 2.2-fold (0.35 log units) above; measured number inside the range.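

In this assay the carbonyl carbon now gives a step that clears the scatter: an at least 2.7-fold lower number from compound 2 to compound 3 (0.44 log units; beyond the scatter). Compound 2 stands at > 100000 nM, which is a limit of the assay, so the size of that step is known only as a floor: the limit of > 100000 nM in this assay, at which 1 of the 3 values shown sits. The other new step, a 1.5-fold lower number from compound 1 to compound 3 (0.16 log units; within the scatter), leaves 3,4-difluorophenyl and 3,4,5-trimethoxyphenyl unordered, so in this set only the exchange of naphthalen-1-yl for 3,4-difluorophenyl separates two groups at this place.

As far as these compounds go, how far naphthalen-1-yl really lies from the two single-ring aryl groups stays open. Also open, from the compounds shown here alone, is whether an aryl ring bearing an amine or a carboxylic acid, or a plain alkyl chain on the carbonyl carbon, would shift the number away from that of compound 3.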